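Amine side chain variation in the thienopyrimidine urea series

The source may hold more compounds than are shown below. What is called first, only, known or untested is meant among the compounds shown, and "the series" means these compounds.

Measured compounds:
compound 1 `CN(C)CCCNc1nc(-c2ccc(NC(=O)Nc3ccccc3Cl)cc2)nc2ccsc12` — 690 nM
compound 2 `CN(C)CCCNc1nc(-c2ccc(NC(=O)Nc3ccc(Cl)cc3Cl)cc2)nc2ccsc12` — 2270 nM
compound 3 `CCN(CC)CCCNc1nc(-c2ccc(NC(=O)Nc3ccc(C)cc3)cc2)nc2ccsc12` — 1760 nM

In a functional assay on MKN-45 cells (Homo sapiens) for cytotoxicity, read by MTT assay, with a stated time of 72 h (a higher number here means a weaker inhibitor, a lower number a stronger inhibitor), compound 2 gives the highest of the three numbers. Its nearest neighbour is compound 3, whose 1760 nM lies within the scatter of it, so no order between compound 2 and compound 3 can be read. Going by the values given here, compound 1 stands furthest away, with a 3.3-fold higher number from compound 1 to compound 2 (0.52 log units; beyond the scatter) the only single-point step in the set; it concerns the aryl urea and not the amine side chain.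

Compound 4 `CCN(CC)CCNc1nc(-c2ccc(NC(=O)Nc3ccc(Cl)cc3Cl)cc2)nc2ccsc12` is not yet measured. It differs from compound 2 by diethylamino in place of (dimethylamino)methyl on a saturated chain carbon, two bonds along the chain from a nitrogen on an aromatic ring. Among the compounds with values here, no measured step bears on this change: compound 3 carries a diethylamino chain, but it differs from compound 2 in more than one place, so its value cannot be split into parts. For this assay the expectation is therefore no step beyond the scatter, with a 1.1-fold lower number from compound 2 to compound 4 (0.05 log units; within the scatter) as the working assumption. Compound 4 is estimated at 2000 nM, within a range of 700 nM to 6000 nM.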

Compound 4, half-maximal inhibitory concentration: 1520 nM
Estimate against measurement, compound 4: 1.3-fold (0.12 log units) above; low and high end bracket the measured number.
By their numbers in this assay, from the lowest: compound 1; then compounds 4, 3 and 2 (each within the scatter of the next).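

In this assay, going by these compounds alone, going from (3-(dimethylamino)propyl)amino to (2-(diethylamino)ethyl)amino with the aryl urea held constant gives a 1.5-fold lower number from compound 2 to compound 4 (0.17 log units; within the scatter) as the first single-point reading on the amine side chain. At this place on the chain, the change therefore leaves compound 2 and compound 4 indistinguishable, and no order between them can be read. Nothing available here bears on what lies behind this reading.

The step alters chain length and the amine substituents together, so the contribution of each remains unresolved; 2-(dimethylamino)ethyl and 3-(diethylamino)propyl chains on the aryl urea of compound 2 would separate them. From the compounds shown here alone, whether a pyrrolidine or morpholine in place of diethylamino would stay in the same range also remains open.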